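The source may hold more compounds than are shown below. What is called first, only, known or untested is meant among the compounds shown, and "the series" means these compounds.

Values in an assay on CHO cells for displacement of a labelled ligand from melanin-concentrating hormone receptor 1 (Rattus norvegicus), read by scintillation counting, with a stated time of 1 h; on this read-out higher numbers stand for weaker inhibition and lower numbers for stronger inhibition:

compound 1 `Cc1nc2ccc(NC(=O)COc3ccc(OC(F)(F)F)cc3)cn2c1C`: 7.8 nM
compound 2 `Cc1c(C2CC2)nc2ccc(-n3ccc(OCc4ccccc4)cc3=O)cn12`: 28 nM
compound 3 `CCc1nc2ccc(-n3ccc(OCc4ccccc4)cc3=O)cn2c1C`: 120 nM

Compound 2 holds the second highest number of the three, with compound 1 lower and compound 3 higher; the move from compound 2 to compound 3 is a 4.3-fold higher number from compound 2 to compound 3 (0.63 log units; beyond the scatter), a change of the group on an aromatic carbon of the core. Compound 4 `Cc1c(C2CC2)nc2ccc(-n3ccc(OCc4ccccn4)cc3=O)cn12` is compound 2 with pyridin-2-yl in place of phenyl on a saturated chain carbon bound to an oxygen on an aromatic ring. Within the data shown here, no measured pair in this set tests that exchange; the single step known concerns a different place and does not bear on it. The expectation for compound 4 is therefore a step of a 1.4-fold higher number from compound 2 to compound 4 (0.15 log units; within the scatter), likely within the scatter. Compound 4 is estimated at 40 nM, range 12 nM to 130 nM.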

Compound 4, half-maximal inhibitory concentration: 150 nM
Beside the measured number, compound 4's estimate is 3.8-fold (0.57 log units) below it; measured number outside the range, above it.
By their numbers in this assay, from the lowest: compound 1; then compound 2; then compounds 3 and 4 (each within the scatter of the next).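

The group on the saturated chain carbon bound to an oxygen on an aromatic ring proves sensitive: in this assay, pyridin-2-yl in place of phenyl gives a 5.4-fold higher number from compound 2 to compound 4 (0.73 log units; beyond the scatter). Changes at this place, as well as on the aromatic carbon of the core, can therefore move the number beyond the scatter. No measurement at hand accounts for this step.

The compounds shown leave open how pyrimidinyl or cyclohexyl would read at this place. They also leave open whether the same exchange gives a similar step with ethyl on the core.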